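The source may report more compounds than this note shows. Statements on the series, on what has been measured and on what is new or still open speak of the compounds shown alone.

For the measured compounds named here, compound 1 `COCOc1cc(C2=C(c3cc(OC)c(OC)c(OC)c3)C(=O)CC2O[SiH2]C(C)(C)C)ccc1OC` is the one member of this set with an actual number in an ADME assay on KB cells (Homo sapiens) for cytotoxicity, read by MTT assay, with a stated time of 72 h; a higher number here means a weaker inhibitor, a lower number a stronger inhibitor: compound 1 gives 33 ug/mL. Compound 2 `COc1ccc(C2=C(c3cc(OC)c(OC)c(OC)c3)C(=O)CC2C)cc1C(=O)O` reaches only the limit of the assay in this assay, > 100 ug/mL. Compound 3 `COc1cc(C2=C(c3cc(C)c(OC)c(C)c3)C(OC(C)=O)CC2=O)cc(OC)c1OC` likewise shows only a limit in this assay, > 100 ug/mL. Compound 1 thus stands apart from the limit of > 100 ug/mL in this assay, at which 2 of the 3 values shown sit. Compound 4 `COc1ccc(C2=C(c3cc(OC)c(OC)c(OC)c3)C(=O)CC2O[SiH2]C(C)(C)C)cc1` has not yet been measured; it differs from compound 1 by hydrogen in place of methoxymethoxy on an aromatic carbon. Going by the values given here, no pair of measured compounds differs in a single place, so no measured step guides the expectation. The step expected is a 1.2-fold higher number from compound 1 to compound 4 (0.08 log units; within the scatter), small, within the scatter or leaning a little toward weaker inhibition. Compound 4 is therefore estimated at 40 ug/mL, with a range from 15 ug/mL to 100 ug/mL.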

Compound 4, half-maximal inhibitory concentration: > 100 ug/mL
Compound 4: a limit, no number (the forecaster's own chance of this, stated with the estimate: 25%); middle value at least 2.5-fold (0.39 log units) away from the limit.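

In this assay, hydrogen in place of methoxymethoxy on this aromatic carbon gives an at least 3.0-fold higher number from compound 1 to compound 4 (0.48 log units; beyond the scatter), so a change at this position alone can move the result beyond the scatter. Going by these compounds, compound 4 gives only a limit, > 100 ug/mL, so the full size of the step stays unknown. Compound 1 remains the only compound shown with an actual number: the limit of > 100 ug/mL in this assay, at which 3 of the 4 values shown sit.

On these data alone, whether a hydroxyl or an amine on this carbon would keep a measurable value stays open. So does whether methoxymethoxy itself matters or any group there would serve.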